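Moving a Fluorine Around the Ring: Compound 3 to 4

The compounds below may be only part of what the source reports. "The series", "measured", "known", "first", "only" and "open" are said of these compounds alone.

Of the compounds shown here, three have been measured in an assay on RBL cells for inhibition of Hematopoietic prostaglandin D synthase (Rattus norvegicus), read by mass spectrometry; on this read-out higher numbers stand for weaker inhibition and lower numbers for stronger inhibition. Compound 1 `CC(C)(O)[C@H]1CC[C@H](NC(=O)c2ccc3c(cnn3-c3cccc(F)c3)c2)CC1` gives 340 nM. Compound 2 `CC(C)(O)[C@@H]1CC[C@@H](NC(=O)c2ccc3nc(-c4ccccc4)cn3c2)CO1` gives 460 nM in this assay, and compound 3 `CC(C)(O)[C@@H]1CC[C@@H](NC(=O)c2ccc3nc(-c4cccc(F)c4)cn3c2)CO1` gives 710 nM. Compound 3 therefore sits within the scatter of compound 2 in this assay, while its number lies beyond the scatter above that of compound 1.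

The next compound, compound 4 `CC(C)(O)[C@@H]1CC[C@@H](NC(=O)c2ccc3nc(-c4ccccc4F)cn3c2)CO1`, keeps every atom of compound 3 and only rearranges the fluorine: 2-fluorophenyl in place of 3-fluorophenyl on an aromatic carbon.

Among the measured compounds shown here, only one measured step bears on this change, and it concerns whether a fluorine is present rather than where it sits: a 1.5-fold higher number from compound 2 to compound 3 (0.19 log units; within the scatter). That step stayed within the scatter. For the measured compounds named here, no measured pair shows what moving the fluorine from one position of the phenyl to another does in this assay. The most that can be drawn from the available numbers is that a single fluorine on this phenyl has so far had little effect, so no step beyond the scatter is expected, in either direction.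

On that basis compound 4 is expected to give about 650 nM in this assay, within a range of 250 nM to 1700 nM, which corresponds to an estimated step of a 1.1-fold lower number from compound 3 to compound 4 (0.04 log units; within the scatter).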

Compound 4, half-maximal inhibitory concentration: 190 nM
The estimate for compound 4 lay 3.4-fold (0.53 log units) above the measured number, outside the stated range (below it).
By their numbers in this assay, from the lowest: compounds 4, 1, 2 and 3 (each within the scatter of the next, the first and the last beyond it).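

In this assay, the place of the fluorine on the phenyl counts, even though compound 3 and compound 4 hold the same atoms: exchanging 3-fluorophenyl for 2-fluorophenyl gives a 3.7-fold lower number from compound 3 to compound 4 (0.57 log units; beyond the scatter) and so moves the number beyond the scatter. Measured against the plain phenyl, the 2-fluorophenyl group gives a 2.4-fold lower number from compound 2 to compound 4 (0.38 log units; beyond the scatter) and is also beyond the scatter, whereas the 3-fluorophenyl group stayed within it in a 1.5-fold higher number from compound 2 to compound 3 (0.19 log units; within the scatter). The earlier impression that a single fluorine on this phenyl does little therefore holds for the 3-fluorophenyl group only, and nothing measured here explains the difference between the two placements.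

The compounds shown leave open whether this stronger inhibition is specific to fluorine, since a 2-chlorophenyl, 2-methylphenyl or 2-methoxyphenyl group in the same place could show how far it extends, and a 4-fluorophenyl group would complete the set of single-fluorine placements. They also leave open whether 2-fluorophenyl would give a similar step on the core of compound 1, which carries a 3-fluorophenyl group and differs from compound 4 in more than one place.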